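Swapping the Amide Amine: From Diethyl to Hydroxyazetidine

This account rests on a few compounds, and the source may have more. Where it says the series, first, only, none or still open, it means among the compounds named here.

Compound 3 `CCN(CC)C(=O)c1cccn1-c1ccc(Nc2ncc(Cl)c(Nc3ccccc3NS(C)(=O)=O)n2)c(OC)c1` gives 870 nM in a functional assay on NCI-H2228 cells (Homo sapiens) for antiproliferative activity, read by MTT assay, with a stated time of 72 h (on this read-out lower numbers stand for stronger inhibition and higher numbers for weaker inhibition), the second highest of the three numbers seen so far. Compound 1 `COC(=O)c1cccn1-c1ccc(Nc2ncc(Cl)c(Nc3ccccc3NS(C)(=O)=O)n2)c(OC)c1` gives 950 nM, and compound 2 `COc1cc(-n2cccc2C(=O)N(C)C)ccc1Nc1ncc(Cl)c(Nc2ccccc2NS(C)(=O)=O)n1` gives 54 nM. The step of a 1.1-fold lower number from compound 1 to compound 3 (0.04 log units; within the scatter) is thus unremarkable, whereas a 16-fold higher number from compound 2 to compound 3 (1.21 log units; beyond the scatter) is large. Compound 4 `COc1cc(-n2cccc2C(=O)N2CC(O)C2)ccc1Nc1ncc(Cl)c(Nc2ccccc2NS(C)(=O)=O)n1` carries 3-hydroxyazetidin-1-yl in place of diethylamino on a carbonyl carbon. Three changes at this carbonyl carbon have been measured: an 18-fold lower number from compound 1 to compound 2 (1.25 log units; beyond the scatter) and a 16-fold higher number from compound 2 to compound 3 (1.21 log units; beyond the scatter) were both large, while a 1.1-fold lower number from compound 1 to compound 3 (0.04 log units; within the scatter) stayed within the scatter. Among the measured compounds shown here, the entering group matches none of the measured ones, so the expected step of a 3.5-fold lower number from compound 3 to compound 4 (0.54 log units; beyond the scatter) is a moderate lowering, well short of the gain seen with compound 2. Compound 4 is therefore estimated at 250 nM, with a range from 60 nM to 1000 nM.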

Compound 4, half-maximal inhibitory concentration: 44 nM
The estimate for compound 4 lay 5.7-fold (0.75 log units) above the measured number, and the stated range ends above it.
By their numbers in this assay, from the lowest: compounds 4 and 2 (each within the scatter of the next); then compounds 3 and 1 (each within the scatter of the next).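

In this assay the step from diethylamino to 3-hydroxyazetidin-1-yl is large (a 20-fold lower number from compound 3 to compound 4 (1.30 log units; beyond the scatter)), as is the step from methoxy (a 22-fold lower number from compound 1 to compound 4 (1.33 log units; beyond the scatter)), while the step from dimethylamino stays within the scatter (a 1.2-fold lower number from compound 2 to compound 4 (0.09 log units; within the scatter)). Dimethylamino is thus no longer the only group on this carbonyl carbon to reach this level, and since 3-hydroxyazetidin-1-yl equals diethylamino in heavy atoms, that count alone does not set the number here. Nothing available explains this result. Going by these compounds, whether the hydroxyl or the four-membered ring goes with the lower number remains open. An azetidin-1-yl amide without the hydroxyl, set beside an open 2-hydroxyethylamino amide, would separate the two.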